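A few compounds are considered here, and "the series" means these few. Any claim that something is new, unique, unknown or untested is made for them only; others in the source may bear on it.

Compound 2, with the structure `CN(CC1CCOCC1)N(c1cc(C#CC(C)(C)C)sc1C(=O)O)C(=O)[C@H]1CC[C@H](C)CC1`, stands at a limit in an ADME assay on Huh-7 cells (Homo sapiens) for cytotoxicity, read by fluorescence, with a stated time of 3 days; a lower number here means that less compound is tolerated, a higher number that more compound is tolerated: in this assay compound 2 gives > 44000 nM, which is a limit rather than a measured number. Within the data shown here, its one measured neighbour, compound 1 with the structure `CN([C@H]1CC[C@H](O)CC1)N(c1cc(C#CC(C)(C)C)sc1C(=O)O)C(=O)[C@H]1CC[C@H](C)CC1`, is in the same position, for in this assay compound 1 gives > 44000 nM, again a limit. Among the measured compounds shown here, the step that the two limits leave unreadable from compound 1 to compound 2 therefore cannot be read, and the only evidence on the measured pair is the limit of > 44000 nM in this assay, at which 2 of the 2 values shown sit. Compound 3, with the structure `CN1CCC(N(C)N(c2cc(C#CC(C)(C)C)sc2C(=O)O)C(=O)[C@H]2CC[C@H](C)CC2)CC1`, differs from compound 2 by 1-methylpiperidin-4-yl in place of (oxan-4-yl)methyl on an amine nitrogen. For the measured compounds named here, no measured step bears on this change with a readable size, since the one step between measured compounds, a step that the two limits leave unreadable from compound 1 to compound 2, sits between two limits. On that footing the step of a number no higher from compound 2 to compound 3 (the limit leaves the size open) is expected to show nothing beyond the usual scatter, with a reading that most probably again falls at the limit. For compound 3 the estimate in this assay is 44000 nM, within a range from 20000 nM to 100000 nM.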

Compound 3, half-maximal cytotoxic concentration: > 44000 nM
Compound 3: no number, only a limit; the forecaster's own chance of this, stated with the estimate: 80%; the middle value sits exactly at the limit.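

In this assay compound 3 gives > 44000 nM, which is a limit, so its steps from compound 1 and from compound 2 cannot be read. The compounds shown leave open where the half-maximal cytotoxic concentration of each lies and whether the changes on the amine nitrogen alter it, the only evidence being this: the limit of > 44000 nM in this assay, at which 3 of the 3 values shown sit.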